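Fluorine on the quinoline ring of a cytotoxic anilide

The compounds below may be only part of what the source reports. "The series", "measured", "known", "first", "only" and "open" are said of these compounds alone.

Of the compounds shown here, three of one series have been tested in a functional assay on U-87MG ATCC cells (Homo sapiens) for cytotoxicity, read by MTT assay, with a stated time of 72 h; on this read-out lower numbers stand for stronger inhibition and higher numbers for weaker inhibition. Compound 1, `COc1cc2c(Oc3ccc(NC(=O)c4cc(-c5ccccc5)nc5ccccc45)cc3F)ccnc2cc1OCCCN1CCCCC1`, gives 1490 nM. Compound 2, `COc1cc2c(Oc3ccc(NC(=O)c4cc(-c5ccc(F)cc5)nc5ccccc45)cc3F)ccnc2cc1OCCCN1CCCCC1`, gives 980 nM. The change between them, (fluoro in place of hydrogen on an aromatic carbon), made the step of a 1.5-fold lower number from compound 1 to compound 2 (0.18 log units; within the scatter), so the two values show no clear difference.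

Compound 3, `COc1cc2c(Oc3ccc(NC(=O)c4cc(-c5cccc(Cl)c5)nc5ccccc45)cc3F)ccnc2cc1OCCCN1CCC(C)CC1`, gives 580 nM. Its value stands lowest of the three, but its gap to compound 2 lies within the usual scatter; only the gap to compound 1 lies beyond it. The difference between the core of compound 3 and the core of compound 1 is not broken down here.

Compound 4, `COc1cc2c(Oc3ccc(NC(=O)c4cc(-c5cccc(Cl)c5)nc5ccc(F)cc45)cc3F)ccnc2cc1OCCCN1CCC(C)CC1`, has not yet been measured in this assay . It differs from compound 3 by fluoro in place of hydrogen on an aromatic carbon. Within the data shown here, this is the same kind of change as the one from compound 1 to compound 2, but the place differs: in compound 2 the fluoro sits para to a large group on a ring of carbon only, whereas in compound 4 it sits on a ring that is part of a fused or bridged system of two rings, meta to a fused ring and para to a fused ring.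

Because the earlier step of a 1.5-fold lower number from compound 1 to compound 2 (0.18 log units; within the scatter) was small, a small step is expected here too, and the expected step is a 1.3-fold lower number from compound 3 to compound 4 (0.11 log units; within the scatter). For compound 4 the estimated value in this assay is 450 nM, with a likely range from 200 nM to 1100 nM.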

Compound 4, half-maximal inhibitory concentration: 110 nM
For compound 4 the middle estimate is 4.1-fold (0.61 log units) above the measured one, outside the stated range (below it).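

In this assay, fluoro in place of hydrogen on an aromatic carbon gave a 5.3-fold lower number from compound 3 to compound 4 (0.72 log units; beyond the scatter), and this step does not match the earlier one: the same change on two cores in this assay, a 1.5-fold lower number (0.18 log units; within the scatter) from compound 1 to compound 2 and a 5.3-fold lower number (0.72 log units; beyond the scatter) from compound 3 to compound 4, 3.5-fold (0.54 log units) apart, beyond the scatter of two such steps

This shows that the size of the step seen with one pair did not carry over to the other, so the same kind of change cannot be assumed to give the same result across this series. It does not show what sets the two steps apart, since the fluoro sits on a different ring in each pair and the two pairs also differ elsewhere in the molecule, and one pair of each kind cannot separate the place of the fluoro from the rest of the core.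

Still open, on these data alone, is whether fluoro on the six-membered aromatic ring of carbon only that is part of the fused system would give a step of similar size on the core of compound 1, which would help to tell place from core. Also open, as far as these compounds go, is whether another group at that place on the core of compound 3, such as a methoxy group, a nitrile or an amine, would give a step of similar size, or whether the result is particular to fluoro.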